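Cyclobutyl amide replacing oxanylethyl on the aminopyridine nitrile core

The source may hold more compounds than are shown below. What is called first, only, known or untested is meant among the compounds shown, and "the series" means these compounds.

Compound 3 `N#Cc1cnc(NCc2cnccc2C(F)(F)F)cc1NCCC1CCOCC1` gives 1200 nM in an assay on isolated protein for inhibition of protein kinase C theta type (Homo sapiens), read by TR-FRET, with a stated time of 2 h (on this read-out higher numbers stand for weaker inhibition and lower numbers for stronger inhibition), the highest number among the three measured compounds. Compound 1 `N#Cc1cnc(NCc2cnccc2C(F)(F)F)cc1N[C@H]1C[C@@H](O)C1` gives 500 nM and compound 2 `N#Cc1cnc(NCc2cnccc2C(F)(F)F)cc1NC[C@H]1CC[C@H](O)CC1` gives 50 nM in this assay; the step of a 24-fold higher number from compound 2 to compound 3 (1.38 log units; beyond the scatter) is the largest in the set, and the step of a 2.4-fold higher number from compound 1 to compound 3 (0.38 log units; beyond the scatter) is smaller but still beyond the scatter. Compound 4 `CC1(C)[C@@H](Nc2cc(NCc3cnccc3C(F)(F)F)ncc2C#N)C[C@H]1C(N)=O` carries 3-carbamoyl-2,2-dimethylcyclobutyl in place of 2-(oxan-4-yl)ethyl on a nitrogen on an aromatic ring. The two measured steps into compound 3 both bear on this change: each brought a ring bearing a hydrogen-bond donor and gave a lower number than the 2-(oxan-4-yl)ethyl group, and compound 4 likewise returns to a ring with one hydrogen-bond donor attached directly to the aromatic nitrogen, as in compound 1. Among the compounds with values here, the closest measured analogue is therefore compound 1, whose 3-hydroxycyclobutyl gave the step of a 2.4-fold higher number from compound 1 to compound 3 (0.38 log units; beyond the scatter) in reverse; the carbamoyl and the two methyl groups on the four-membered ring have no measured counterpart here, so the expected step of a 4.0-fold lower number from compound 3 to compound 4 (0.60 log units; beyond the scatter) for compound 4 is estimated as a modest lowering with a wide range. Compound 4 is expected to give 300 nM in this assay, within 60 nM to 1500 nM.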

Compound 4, half-maximal inhibitory concentration: 140 nM
Estimate against measurement, compound 4: 2.1-fold (0.33 log units) above, within the range that was stated.
By their numbers in this assay, from the lowest: compound 2; then compound 4; then compound 1; then compound 3.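

Working notes on the group on the nitrogen on an aromatic ring: in this assay, the 3-carbamoyl-2,2-dimethylcyclobutyl group gives an 8.6-fold lower number from compound 3 to compound 4 (0.93 log units; beyond the scatter) and so extends the donor-bearing groups that lower the number beyond the hydroxyl-bearing rings seen earlier. The same group gives a 3.6-fold lower number from compound 1 to compound 4 (0.55 log units; beyond the scatter) against the other four-membered ring, yet still a 2.8-fold higher number from compound 2 to compound 4 (0.45 log units; beyond the scatter) against the (4-hydroxycyclohexyl)methyl group, so a hydrogen-bond donor on the ring does not by itself fix the value, and compound 2 remains lowest. No supporting data on the origin of these differences accompany the series.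

On these data alone, the carbamoyl, the methyl groups and the defined stereochemistry all change together, so their separate contributions stay open; the same four-membered ring without the methyl groups, or the opposite stereoisomer of compound 4, would divide them. Also open, as far as these compounds go, is how a carboxylic acid or a primary amine would compare with the carbamoyl on this ring, and whether a carbamoyl on the cyclohexylmethyl group of compound 2 would lower the number further.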